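From pyridin-3-yl to 1,3-oxazol-4-yl on a carbonyl carbon

The source may hold more compounds than are shown below. What is called first, only, known or untested is meant among the compounds shown, and "the series" means these compounds.

- Compound 1 (`CC(C)(C)C(=O)n1nccc1-c1ccccc1`) gives 8.3
- Compound 2 (`O=C(c1cscn1)N1CCC(C(=O)N2N=CC[C@H]2c2ccccc2)CC1`) gives 3
- Compound 3 (`O=C(c1cccnc1)N1CCC(C(=O)N2N=CCC2c2ccccc2)CC1`) gives 2.6

In a physicochemical assay for lipophilicity, read by HPLC, measured as chromatographic lipophilicity, at pH 7.4 (on this read-out lower numbers stand for lower lipophilicity and higher numbers for higher lipophilicity), compound 3 holds the lowest of these three numbers, with compound 2 the nearest and compound 1 the furthest, both beyond the usual scatter. Compound 4 (`O=C(c1cocn1)N1CCC(C(=O)N2N=CCC2c2ccccc2)CC1`) is compound 3 with 1,3-oxazol-4-yl in place of pyridin-3-yl on a carbonyl carbon. Within the data shown here, no measured pair shows a single change of this kind, so the evidence is thin. With compound 2 at 3 and compound 3 at 2.6 as the closest guides, a small downward step within the scatter is expected. The estimated a number 0.10 log units lower from compound 3 to compound 4 (within the scatter) is therefore small. Compound 4 is expected at 2.5 with a range from 2.1 to 2.9 in this estimate.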

Compound 4, distribution coefficient: 2.9
The estimate for compound 4 lay 0.40 log units below the measured number, and the stated range covers the measured number.
By their numbers in this assay, from the lowest: compounds 3, 4 and 2 (each within the scatter of the next, the first and the last beyond it); then compound 1.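

In this assay, among these compounds, placing 1,3-oxazol-4-yl in position of pyridin-3-yl on this carbonyl carbon gives a number 0.30 log units higher from compound 3 to compound 4 (within the scatter), the first comparison here in which only one place changes. At this position, then, a six-membered aromatic ring with 1 hetero atom and a five-membered aromatic ring with 2 hetero atoms cannot be told apart on this read-out. Nothing measured here offers a reason for this result.

Still open, going by these compounds, is whether a non-aromatic group at this position, such as an amine or a carboxylic acid, would shift the number beyond the scatter.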